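The source may hold more compounds than are shown below. What is called first, only, known or untested is meant among the compounds shown, and "the series" means these compounds.

Measured so far in a functional assay on HEK293 cells with D(4) dopamine receptor (Homo sapiens) as the target, read by FLIPR; on this read-out higher numbers stand for larger maximal responses and lower numbers for smaller maximal responses:
- compound 1, `O/N=C(\CCN1CCN(c2ccccn2)CC1)c1ccc(Cl)cc1`: 46%
- compound 2, `CO/N=C(\CCN1CCN(c2ccccn2)CC1)c1ccc(Cl)cc1`: 87%
- compound 3, `CO/N=C(/CCN1CCN(c2ccccn2)CC1)c1ccc(Cl)cc1`: 68%

Compound 2 stands highest of the three numbers in this assay. Its nearest neighbour is compound 3, and the step of a number 19 percentage points lower from compound 2 to compound 3 (beyond the scatter) rests on the fact that compounds 2 and 3 differ only in the configuration as drawn alone. Its furthest neighbour is compound 1, and the step of a number 41 percentage points higher from compound 1 to compound 2 (beyond the scatter) is the largest movement seen in the set so far.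

Compound 4, `CO/N=C(/c1ccc(Cl)cc1)C(COC(C)C)CN1CCN(c2ccccn2)CC1`, is not yet measured in this assay. Relative to compound 2 the change is isopropoxymethyl in place of hydrogen on a saturated chain carbon bound to a carbon with a double bond to nitrogen and a saturated chain carbon. Neither measured step bears on this change directly: the step from compound 1 to compound 2 concerns the oxygen of the shared core, and the step from compound 2 to compound 3 concerns only the configuration as drawn. Within the data shown here, the saturated chain carbon of the shared core carries hydrogen in every measured compound, so there is no measured step on that position to draw from.

The expectation for compound 4 therefore rests on the values of compound 2 and compound 3 as the range within which the methylated oxime has been seen, with wide uncertainty. A modest step of a number 17 percentage points lower from compound 2 to compound 4 (beyond the scatter) is expected, downward, but its size cannot be anchored on the measured steps. For compound 4 the estimate in this assay is 70%, within a range from 40% to 95%.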

Compound 4, largest response reached (reported as efficacy), in percent of the reference or control that the assay uses: 60%
Compound 4: the middle estimate sits 10 percentage points above what was measured; measured number inside the range.
By their numbers in this assay, from the lowest: compound 1; then compounds 4 and 3 (each within the scatter of the next); then compound 2.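

In this assay the saturated chain carbon bound to a carbon with a double bond to nitrogen and a saturated chain carbon now shows itself to be a position that moves the maximal response: isopropoxymethyl in place of hydrogen gives a number 27 percentage points lower from compound 2 to compound 4 (beyond the scatter) on the methylated oxime. The response is reduced but not lost, as compound 4 still reaches 60% with this group of 5 heavy atoms in place, so the position accepts a branched ether side chain with part of the response kept. The data shown give no reason for this step.

A single substituent cannot separate the contributions of the ether oxygen, the isopropyl end and the overall length of the group, so a plain methyl, a hydroxymethyl or a longer unbranched alkyl chain on the same carbon would be the informative comparison. Also open, on these data alone, is whether an amine at this carbon would behave alike, and whether the isopropoxymethyl group has the same effect on the oxime of the opposite configuration.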